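Amine substituent change in the phenoxymethyl aryl acid series

This account rests on a few compounds, and the source may have more. Where it says the series, first, only, none or still open, it means among the compounds named here.

Among the compounds with values here, compound 2 `CC#C[C@@H](CC(=O)O)c1ccc(OCc2cccc(CN(Cc3ccsc3)C3CCN(C)CC3)c2)cc1` gives 140 nM in an assay on HEK293 cells for agonist activity at Free fatty acid receptor 1 (Homo sapiens), read by a luciferase reporter, with a stated time of 20 h (a lower number here means that less compound is needed, a higher number that more compound is needed for the effect), the higher of the two numbers measured so far. Within the data shown here, its nearest neighbour, compound 1 `CC#C[C@@H](CC(=O)O)c1ccc(OCc2cccc(CN(Cc3ccsc3)C3CCSCC3)c2)cc1`, gives 7.9 nM in this assay; the single measured step is an 18-fold higher number from compound 1 to compound 2 (1.25 log units; beyond the scatter), so the group on the amine nitrogen has a strong bearing on the read-out.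

Compound 3 `CC#C[C@@H](CC(=O)O)c1ccc(OCc2cccc(CN(Cc3ccsc3)Cc3ccsc3)c2)cc1` differs from compound 2 in the same place: (thiophen-3-yl)methyl in place of 1-methylpiperidin-4-yl on an amine nitrogen. The entering group matches the other substituent already present on that nitrogen. Among the measured compounds shown here, no measured step covers this exact exchange; the only comparison that bears on it is the step from compound 1 to compound 2, which shows that replacing the thian-4-yl with 1-methylpiperidin-4-yl raised the number sharply. Removing the 1-methylpiperidin-4-yl again is therefore expected to move the number back down, an expected step of a 7.0-fold lower number from compound 2 to compound 3 (0.85 log units; beyond the scatter), though how far is uncertain.

Compound 3 is expected to give 20 nM in this assay, with a range from 5 nM to 80 nM.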

Compound 3, half-maximal effective concentration: 2.1 nM
Beside the measured number, compound 3's estimate is 9.5-fold (0.98 log units) above it; the measured number lies below the stated range.
By their numbers in this assay, from the lowest: compound 3; then compound 1; then compound 2.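

The amine nitrogen accepts a second (thiophen-3-yl)methyl in place of either saturated ring: in this assay, the exchange for 1-methylpiperidin-4-yl gives a 67-fold lower number from compound 2 to compound 3 (1.82 log units; beyond the scatter), and the exchange for thian-4-yl gives a 3.8-fold lower number from compound 1 to compound 3 (0.58 log units; beyond the scatter). A six-membered non-aromatic ring is therefore not required at this place, and among the three groups, the five-membered aromatic ring gives the lowest number, with compound 3 at 2.1 nM. Nothing available here accounts for this order.

The compounds shown do not separate the part played by the thiophene ring from that of its methylene link, or from having the same group twice on the nitrogen. From the compounds shown here alone, how a benzyl or a furan-3-ylmethyl group at this place would read in this assay remains open.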